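Methyl on an Aromatic Carbon, Judged from Limits

The source may hold more compounds than are shown below. What is called first, only, known or untested is meant among the compounds shown, and "the series" means these compounds.

Compound 1 `O=c1cc(CC(O)COCc2ccccc2)[nH]c(=O)[nH]1` and compound 2 `Cc1c(CC(O)COCc2ccccc2)[nH]c(=O)[nH]c1=O` share a core; compound 2 carries methyl in place of hydrogen on an aromatic carbon. In a functional assay on MIA PaCa-2 cells (Homo sapiens) for antiproliferative activity, read by MTT assay, with a stated time of 72 h (on this read-out higher numbers stand for weaker inhibition and lower numbers for stronger inhibition), compound 1 gives > 100000 nM, a limit of the assay rather than a number. Compound 2 likewise gives only a limit, > 100000 nM. The step that the two limits leave unreadable from compound 1 to compound 2 therefore cannot be read. Compound 3 `C[Si](C)(C)CCOCn1c(CC(O)CO)cc(=O)[nH]c1=O` differs from compound 1 in more than one place; the difference between the two cores is not broken down here. Compound 3 also gives only a limit, > 100000 nM. Compound 4 `Cc1c(CC(O)CO)n(COCC[Si](C)(C)C)c(=O)[nH]c1=O` carries the same kind of change, (methyl in place of hydrogen on an aromatic carbon); the surroundings differ, the carbon being ortho to a 2,3-dihydroxypropyl group and meta to a group of 8 heavy atoms. Because every value seen sits at the limit of > 100000 nM in this assay, at which 3 of the 3 values shown sit, the step is expected to be a step that the limit leaves unreadable from compound 3 to compound 4. Compound 4 is therefore estimated at 150000 nM, most likely again reported only as a limit.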

Compound 4, half-maximal inhibitory concentration: > 100000 nM
Compound 4: no number, only a limit; the forecaster's own chance of this, stated with the estimate: 85%; the middle value does not contradict the limit.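

Compound 3 and compound 4 both give only a limit rather than a number, so no step can be read between them: the limit of > 100000 nM in this assay, at which 4 of the 4 values shown sit. The compounds shown leave open what methyl in place of hydrogen on an aromatic carbon does in this assay.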